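The compounds below may be only part of what the source reports. "The series", "measured", "known", "first", "only" and "open" are said of these compounds alone.

For the measured compounds named here, compound 1 `CC1(C)[C@H]2CC[C@]1(C)N(Cc1cn(-c3cccc(C#N)c3)nn1)C(=O)C2` gives 250 nM in a functional assay on SGC-7901 cells (Homo sapiens) for inhibition, read by MTT assay, with a stated time of 24 h (on this read-out higher numbers stand for weaker inhibition and lower numbers for stronger inhibition), the highest of the two numbers so far; compound 2 `CC1(C)[C@H]2CC[C@]1(C)N(Cc1cn(-c3cccc(Br)c3)nn1)C(=O)C2` gives 120 nM, and the step of a 2.1-fold lower number from compound 1 to compound 2 (0.32 log units; beyond the scatter) is the nearest comparison. Compound 3 `CC1(C)[C@H]2CC[C@]1(C)N(Cc1cn(-c3ccc(Cl)cc3)nn1)C(=O)C2` differs from compound 1 by 4-chlorophenyl in place of 3-cyanophenyl on an aromatic nitrogen. Going by the values given here, only that bromo-for-cyano step bears on the change: a halogen again replaces the nitrile, so a similar modest lowering is expected, a 1.7-fold lower number from compound 1 to compound 3 (0.22 log units; within the scatter), with a fair chance of no step beyond the scatter. Compound 3 is therefore estimated at 150 nM, in the range 60 nM to 400 nM.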

Compound 3, half-maximal inhibitory concentration: 410 nM
Beside the measured number, compound 3's estimate is 2.7-fold (0.44 log units) below it; measured number above the stated range.
By their numbers in this assay, from the lowest: compound 2; then compounds 1 and 3 (each within the scatter of the next).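

In this assay, 4-chlorophenyl in place of 3-cyanophenyl on the aromatic nitrogen leaves compound 3 within the scatter of compound 1 (a 1.6-fold higher number from compound 1 to compound 3 (0.21 log units; within the scatter)). Against 3-bromophenyl, the same position gives a step beyond the scatter (a 3.4-fold higher number from compound 2 to compound 3 (0.53 log units; beyond the scatter)), so a halogen on the phenyl ring does not by itself match compound 2. No evidence at hand gives a cause for these steps.

The compounds shown do not separate the identity of the halogen from its place on the phenyl ring. On these data alone, how an amine or a carboxylic acid on that ring would read remains open.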